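Aryl amide variation on the carbonyl carbon

The compounds below may be only part of what the source reports. "The series", "measured", "known", "first", "only" and "open" are said of these compounds alone.

Measured in a functional assay on Ramos cells (Homo sapiens) for antiproliferative activity, read by CCK-8 assay, with a stated time of 72 h, tested at 40 uM; on this read-out lower numbers stand for less inhibition and higher numbers for more inhibition at the one concentration tested (going by the name of the read-out):
compound 1 `CN1CCN(c2ccc(Nc3nc(-c4cccc(NC(=O)c5cccc(F)c5)c4)sc3C(=O)O)cc2)CC1` gives 82.7%
compound 2 `CN1CCN(c2ccc(Nc3nc(-c4cccc(NC(=O)c5ccccc5)c4)sc3C(N)=O)cc2)CC1` gives 98.1%
compound 3 `CN1CCN(c2ccc(Nc3nc(-c4cccc(NC(=O)c5cccc(F)c5)c4)sc3C(N)=O)cc2)CC1` gives 16.2%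

Compound 3 stands lowest of the three numbers. The two single-change steps leading to it are both large: a number 66.5 percentage points lower from compound 1 to compound 3 (beyond the scatter) and a number 81.9 percentage points lower from compound 2 to compound 3 (beyond the scatter).

Compound 4 `CN1CCN(c2ccc(Nc3nc(-c4cccc(NC(=O)c5ccc(C(F)(F)F)cn5)c4)sc3C(N)=O)cc2)CC1` differs from compound 3 by 5-(trifluoromethyl)pyridin-2-yl in place of 3-fluorophenyl on a carbonyl carbon. Among the measured compounds shown here, of the measured steps, only the one from compound 2 to compound 3 touches the same amide aryl group, and there a single fluoro in place of hydrogen moved the read-out by a large amount; the step from compound 1 to compound 3 concerns the other carbonyl group and does not bear on this change. For the measured compounds named here, with only one relevant step, and that one pointing to a strong sensitivity of this position, the direction for compound 4 cannot be fixed; a large step in either direction is possible. The estimate for compound 4 in this assay is therefore 45%, between 10% and 90%, expected as a step of a number 28.8 percentage points higher from compound 3 to compound 4 (beyond the scatter).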

Compound 4, a percentage reported as inhibition, at one concentration (the size of the read-out at that concentration, not a potency): 96.6%
Beside the measured number, compound 4's estimate is 51.6 percentage points below it, and the stated range ends below it.
By their numbers in this assay, from the lowest: compound 3; then compound 1; then compounds 4 and 2 (each within the scatter of the next).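

In this assay the step of a number 80.4 percentage points higher from compound 3 to compound 4 (beyond the scatter) shows that a larger aryl group on this carbonyl carbon can carry a high number, so the low number of compound 3 does not extend to every replacement of the phenyl of compound 2. The step of a number 1.5 percentage points lower from compound 2 to compound 4 (within the scatter) leaves 5-(trifluoromethyl)pyridin-2-yl and phenyl indistinguishable at this one concentration, so among the amides with the amino group on the other carbonyl only compound 3 reads low, while compound 1, with the same 3-fluorophenyl, does not share that low number. Nothing at hand explains the low number of compound 3.

The compounds shown leave open whether the ring nitrogen or the trifluoromethyl group matters more, as none carries one without the other. Also open, as far as these compounds go, is how a plain pyridin-2-yl, or a phenyl bearing an amine, would read in this assay at this position.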